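Propyl in Place of Bromo: From Compound 2 to Compound 4

A few compounds are considered here, and "the series" means these few. Any claim that something is new, unique, unknown or untested is made for them only; others in the source may bear on it.

Measured compounds in a functional assay for inhibition, with Homo sapiens as the target; a lower number here means a stronger inhibitor, a higher number a weaker inhibitor:
Compound 1 `CCCc1nc(C)c2c(CC)nnc(SC)n12`, measured only as a limit: > 48000 nM
Compound 2 `Oc1nnc(Br)c2c(Br)nc(Br)n12`: 27000 nM
Compound 3 `C=CCn1nc(CCC)c2c(C)nc(CCC)n2c1=O`: 29000 nM

Of the compounds shown here, three have been tested so far. For compound 1 the result is a limit of this assay rather than a number (the limit of > 48000 nM in this assay, at which 1 of the 3 values shown sits). Compound 2 and compound 3 both give numbers, and these two numbers sit within the scatter of each other, so neither can be set apart from the other. Compound 2 is therefore one of two compounds with a measured number, and it is the one from which the next step is taken.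

Compound 4 `CCCc1nc(Br)c2c(Br)nnc(O)n12` has not yet been measured. It differs from compound 2 in one place: propyl in place of bromo on an aromatic carbon. Within the data shown here, no step between measured compounds with this kind of change is available, so there is nothing in the present data that fixes its direction or size. The expectation is that the step from compound 2 to compound 4 in this assay will not exceed the scatter, and the step is estimated as a 1.1-fold higher number from compound 2 to compound 4 (0.05 log units; within the scatter). Compound 4 is accordingly expected to give about 30000 nM in this assay, within a range from 9000 nM to 100000 nM.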

Compound 4, half-maximal inhibitory concentration: 48000 nM
Estimate against measurement, compound 4: 1.6-fold (0.20 log units) below; low and high end bracket the measured number.
By their numbers in this assay, from the lowest: compounds 2, 3 and 4 (each within the scatter of the next).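

In this assay, among these compounds, this is the first step read at this place, on an aromatic carbon of a five-membered aromatic ring with 2 nitrogen, between two ring nitrogen atoms: propyl in place of bromo gives a 1.8-fold higher number from compound 2 to compound 4 (0.25 log units; within the scatter). This single pair shows that the bromo group on this carbon can give way to propyl while the compound still gives a number rather than a limit, and the step does not set the two compounds apart. For compound 1, which differs from the others in more than one place and is not compared with them here, the result remains a limit: the limit of > 48000 nM in this assay, at which 1 of the 4 values shown sits.

The compounds shown leave open what an amine, a carboxylic acid or a chain longer than propyl would do at this place, and whether any group there can move the number beyond the scatter. They also leave open whether propyl in place of bromo would give a step of similar size on the other carbons that bear a bromo group in compound 4.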